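Ester to benzylamide on the shared core

The compounds below may be only part of what the source reports. "The series", "measured", "known", "first", "only" and "open" are said of these compounds alone.

Compounds measured so far:
compound 1 `COc1ccc([N+](=O)[O-])cc1CSc1nc2cc(NC(=O)NC3CC3)ccc2n1C(C)C` — 1900 nM
compound 2 `CCCn1c(SCc2cc([N+](=O)[O-])ccc2OC)nc2cc(NC(=O)NC(C)(C)C)cc(C(=O)OC)c21` — 37 nM

In an assay on isolated protein for inhibition of Gonadotropin-releasing hormone receptor (Homo sapiens) (a higher number here means a weaker inhibitor, a lower number a stronger inhibitor), compound 2 gives 37 nM, the lower of the two numbers measured. Within the data shown here, compound 1 gives 1900 nM in this assay, a gap beyond the scatter; the two differ in several places at once, so no single-point step can be drawn between them.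

Compound 3 `CCCn1c(SCc2cc([N+](=O)[O-])ccc2OC)nc2cc(NC(=O)NC(C)(C)C)cc(C(=O)NCc3ccccc3)c21` follows from compound 2 by one change: benzylamino in place of methoxy on a carbonyl carbon. Among the measured compounds shown here, no comparable step has been measured on this core, so the expectation rests on the change alone. The carbonyl that carries the change is kept, and the change is expected to give a modest step at most, no clear direction, within or near the scatter: compound 3 is estimated at 50 nM in this assay, in a range from 10 nM to 300 nM. This estimate means a step of a 1.4-fold higher number from compound 2 to compound 3 (0.13 log units; within the scatter).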

Compound 3, half-maximal inhibitory concentration: 120 nM
Compound 3: the middle estimate sits 2.4-fold (0.38 log units) below what was measured; low and high end bracket the measured number.
By their numbers in this assay, from the lowest: compound 2; then compound 3; then compound 1.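

In this assay, the shared core now has its first single-change reading at this carbonyl carbon: benzylamino in place of methoxy gives a 3.2-fold higher number from compound 2 to compound 3 (0.51 log units; beyond the scatter), a modest step beyond the scatter. The position therefore accepts the larger benzylamino group, with its six-membered aromatic ring and hydrogen-bond donor, at a limited cost, and compound 3 still reads 120 nM in this assay. Nothing available explains the step.

Still open, as far as these compounds go, is which part of the exchange carries the step: the loss of the methoxy group, the amide hydrogen or the benzyl ring. A carboxylic acid, a primary amide or a methylamino group on the same carbonyl carbon would help separate these parts, and whether the step holds with other substituents elsewhere on the core is also unresolved.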